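Halogen swap on the isatin-derived thiosemicarbazone series

The source may report more compounds than this note shows. Statements on the series, on what has been measured and on what is new or still open speak of the compounds shown alone.

Measured compounds:
compound 1 `O=C1C(=O)N(CN2CCN(c3ccnc4cc(Cl)ccc34)CC2)c2cc(Cl)ccc21` — 47500 nM
compound 2 `O=C1C(=O)N(CN2CCN(c3ccnc4cc(C(F)(F)F)ccc34)CC2)c2ccccc21` — 43900 nM
compound 3 `NC(=S)N/N=C1/C(=O)N(CN2CCN(c3ccnc4cc(Cl)ccc34)CC2)c2cccc(Cl)c21` — 20700 nM

All three values come from an ADME assay on 184B5 cells (Homo sapiens) for cytotoxicity, read by sulforhodamine B assay, with a stated time of 48 h; a higher number here means a weaker inhibitor of growth, a lower number a stronger inhibitor of growth. Compound 3 gives the lowest of the three numbers there; compound 2 lies beyond the scatter above it, and compound 1 is further still, also beyond the scatter. No two of the measured compounds differ in only one place, so no single-point step can be read from them.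

Compound 4 `NC(=S)N/N=C1/C(=O)N(CN2CCN(c3ccnc4cc(Cl)ccc34)CC2)c2cccc(Br)c21` is not yet measured. It differs from compound 3 by bromo in place of chloro on an aromatic carbon. This is a one-atom exchange of one halogen for another at the same aromatic carbon, with nothing else in the structure altered. No comparable exchange exists among the measured compounds to guide the direction, and nothing in the values of compounds 1, 2 and 3 argues for a large effect from such a swap. The expected step of a 1.0-fold lower number from compound 3 to compound 4 (0.01 log units; within the scatter) in this assay is therefore none beyond the scatter, in either direction. Compound 4 is accordingly estimated at 20000 nM, with a range from 9000 nM to 45000 nM.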

Compound 4, concentration for 50% growth inhibition: 46400 nM
Compound 4: middle estimate off by 2.3-fold (0.37 log units), on the low side, and the stated range ends below it.
By their numbers in this assay, from the lowest: compound 3; then compounds 2, 4 and 1 (each within the scatter of the next).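

In this assay, going by these compounds alone, bromo in place of chloro on this aromatic carbon gives a 2.2-fold higher number from compound 3 to compound 4 (0.35 log units; beyond the scatter), the first step that can be read at a single place. The step is modest but lies beyond the scatter, so this position is not indifferent to the identity of the halogen, and of the two halogens compared here, chloro gives the lower number. Nothing measured for these compounds accounts for the change.

As far as these compounds go, with only chloro and bromo compared, the step gives no trend for this carbon, and the outcome with fluoro, methyl, methoxy or an amine there remains open. Also open, from the compounds shown here alone, is whether the same exchange would give a similar step on a compound carrying the ring carbonyl of compounds 1 and 2 in place of the thiosemicarbazone.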